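The source may hold more compounds than are shown below. What is called first, only, known or untested is meant among the compounds shown, and "the series" means these compounds.

Compound 1 `Cc1cc(F)c(S(C)(=O)=O)cc1C(=O)N=C(N)N` gives 44 nM in a functional assay for inhibition of sodium/hydrogen exchanger (Oryctolagus cuniculus) (a higher number here means a weaker inhibitor, a lower number a stronger inhibitor), the higher of the two numbers in hand. Compound 2 `Cc1cc(Br)c(S(C)(=O)=O)cc1C(=O)N=C(N)N` gives 12 nM in this assay, and the step of a 3.7-fold lower number from compound 1 to compound 2 (0.56 log units; beyond the scatter) is the only measured one. Compound 3 `CS(=O)(=O)c1cc(C(=O)N=C(N)N)c(F)cc1F` differs from compound 1 by fluoro in place of methyl on an aromatic carbon. Going by the values given here, the measured step concerns a different site and a different exchange, so it offers no direct guide; no step removing the methyl exists. The expectation is therefore a step of a 1.4-fold higher number from compound 1 to compound 3 (0.13 log units; within the scatter) of little size, with wide uncertainty. Compound 3 is estimated at 60 nM, in the range 20 nM to 180 nM.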

Compound 3, half-maximal inhibitory concentration: 630 nM
Compound 3: the middle estimate sits 11-fold (1.02 log units) below what was measured; the measured number lies above the stated range.
By their numbers in this assay, from the lowest: compound 2; then compound 1; then compound 3.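

At the aromatic carbon ortho to a group of 6 heavy atoms and para to a methylsulfonyl group, fluoro in place of methyl gives a 14-fold higher number from compound 1 to compound 3 (1.16 log units; beyond the scatter) in this assay. This position is therefore sensitive to the exchange, even though the group leaving and the group entering each count 1 heavy atom. No measurement in hand bears on the cause of this step. The compounds shown do not separate the loss of methyl from the entry of fluoro. As far as these compounds go, how an ethyl chain, an amine or bare hydrogen would read at this position remains open.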